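The compounds below may be only part of what the source reports. "The series", "measured", "known", "first", "only" and "open" are said of these compounds alone.

Measured so far:
- compound 1, `Cc1cc(Cl)cc(-c2ccnc3cc(CN4C(=O)CCC4=O)sc23)c1O[C@@H]1CCNC[C@@H]1C`: 2.1 nM
- compound 2, `Cc1cc(Cl)cc(-c2ccnc3cc(CN4C(=O)CCC4=O)sc23)c1CN1[C@@H](C)CNC[C@@H]1C`: 0.32 nM

In an assay on isolated protein for inhibition of ubiquitin carboxyl-terminal hydrolase 7 (Homo sapiens), read by fluorescence, with stated times of 30 min and 1 h (on this read-out higher numbers stand for weaker inhibition and lower numbers for stronger inhibition), compound 2 gives 0.32 nM, the lowest of the two numbers seen. For the measured compounds named here, its only neighbour is compound 1, and the single measured step, a 6.6-fold lower number from compound 1 to compound 2 (0.82 log units; beyond the scatter), came from exchanging (3-methylpiperidin-4-yl)oxy for (2,6-dimethylpiperazin-1-yl)methyl on the shared core.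

Compound 3, `Cc1cc(Cl)cc(-c2ccnc3cc(CN4C(=O)CCC4=O)sc23)c1O[C@H]1CCCNC1`, is the next compound to be tested. Relative to compound 2 the change is (piperidin-3-yl)oxy in place of (2,6-dimethylpiperazin-1-yl)methyl on an aromatic carbon. This largely undoes the earlier step: the (2,6-dimethylpiperazin-1-yl)methyl that brought the lower number in compound 2 is removed, and a (piperidin-3-yl)oxy group, resembling the (3-methylpiperidin-4-yl)oxy of compound 1 though lacking its methyl and attached at a different ring position, takes its place. Because a 6.6-fold lower number from compound 1 to compound 2 (0.82 log units; beyond the scatter) was a modest step beyond the scatter, a step of roughly that size in the opposite direction is expected, bringing compound 3 close to compound 1. In this assay compound 3 is estimated at 2 nM, within a range of 0.7 nM to 7 nM. That estimate means a step of a 6.3-fold higher number from compound 2 to compound 3 (0.80 log units; beyond the scatter).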

Compound 3, half-maximal inhibitory concentration: 4.6 nM
For compound 3 the middle estimate is 2.3-fold (0.36 log units) below the measured one; measured number inside the range.
By their numbers in this assay, from the lowest: compound 2; then compound 1; then compound 3.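

In this assay, replacing the (2,6-dimethylpiperazin-1-yl)methyl with (piperidin-3-yl)oxy gives a 14-fold higher number from compound 2 to compound 3 (1.16 log units; beyond the scatter), so both piperidine groups attached through oxygen, in compound 1 and compound 3, now read weaker than the piperazine group of compound 2, and none of the three compounds goes against this. The oxygen-linked groups also differ from each other, with a 2.2-fold higher number from compound 1 to compound 3 (0.34 log units; beyond the scatter), which shows that this position responds to a change in the piperidine itself and not only to the swap of piperidine for piperazine. No measurement here accounts for either step.

The step between compound 1 and compound 3 removes the methyl and moves the ring attachment together, so the share of each remains unresolved, as does whether the low number of compound 2 comes from its piperazine ring, its two methyl groups or its carbon link to the core. A plain (piperazin-1-yl)methyl without the two methyl groups, or an unsubstituted piperidin-4-yl on the same oxygen, would be the closest groups for separating these effects.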